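Amine substituent change on the compound 1 core

The source may report more compounds than this note shows. Statements on the series, on what has been measured and on what is new or still open speak of the compounds shown alone.

Measured compounds:
compound 1 `CCc1nc(-c2ccc(Cl)cc2Cl)c(CC)nc1NC(CC)CC`: 4.1 nM
compound 2 `CCc1nc(-c2ccc(Cl)cc2Cl)c(OC)nc1NC(CC)CC`: 8 nM
compound 3 `CCc1nc(NC(CC)CC)c(I)nc1-c1ccc(Cl)cc1Cl`: 12 nM

In an assay on IMR-32 cells for displacement of a labelled ligand from corticotropin-releasing factor receptor 1 (Homo sapiens), read by scintillation counting, with a stated time of 2 h (a lower number here means a stronger inhibitor, a higher number a weaker inhibitor), compound 1 gives the lowest number of the three measured compounds. Compound 2 comes nearest, the step being a 2.0-fold higher number from compound 1 to compound 2 (0.29 log units; within the scatter), which leaves the two compounds indistinguishable by this measure. Compound 3 lies furthest away, with a 2.9-fold higher number from compound 1 to compound 3 (0.47 log units; beyond the scatter), a modest step toward weaker binding.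

The next compound, compound 4 `CCc1nc(-c2ccc(Cl)cc2Cl)c(CC)nc1NC(C1CC1)C1CC1`, keeps the core of compound 1 and changes the substituent on the amine: dicyclopropylmethyl in place of pentan-3-yl on a nitrogen on an aromatic ring. Neither measured step bears directly on this change. Among the measured compounds shown here, both of them alter a group on an aromatic carbon of the core, not on the nitrogen on an aromatic ring, so the series so far gives no direct reading of how this assay responds to a change at that position. What the measured steps do show is that the core tolerates small changes with, at most, a modest loss. On that basis the estimate for compound 4 in this assay is a step of a 1.5-fold higher number from compound 1 to compound 4 (0.17 log units; within the scatter), small in either direction and not confidently beyond the scatter. Compound 4 is therefore expected to give about 6 nM in this assay, with the range taken as 1.5 nM to 25 nM.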

Compound 4, inhibition constant: 3.7 nM
The estimate for compound 4 lay 1.6-fold (0.21 log units) above the measured number, and the stated range covers the measured number.
By their numbers in this assay, from the lowest: compounds 4, 1, 2 and 3 (each within the scatter of the next, the first and the last beyond it).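

Among the compounds shown here, this is the first reading at the nitrogen on an aromatic ring: in this assay the exchange of pentan-3-yl for dicyclopropylmethyl gives a 1.1-fold lower number from compound 1 to compound 4 (0.04 log units; within the scatter) and leaves the two compounds indistinguishable by this measure. The substituent on that nitrogen can thus go from a group with no ring and 5 heavy atoms to one with 2 three-membered non-aromatic rings of carbon only and 7 heavy atoms, with no loss beyond the scatter, while on the aromatic carbon the shown changes include a 2.9-fold higher number from compound 1 to compound 3 (0.47 log units; beyond the scatter) and so a step that does pass the scatter. No supporting data are available to explain why this exchange leaves the binding number within the scatter.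

The compounds shown carry only branched all-carbon groups on that nitrogen, so a single cyclopropylmethyl, a benzyl group or a chain ending in a hydroxyl or an ether oxygen would test how far this tolerance extends. On these data alone, it also remains open whether dicyclopropylmethyl behaves the same way alongside the methoxy of compound 2 or the iodo of compound 3.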